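This account rests on a few compounds, and the source may have more. Where it says the series, first, only, none or still open, it means among the compounds named here.

Compound 1 `CCOC(=O)/C=C/c1ccc(OC)c(OC(=O)c2nc(C)c(C)nc2C)c1` and compound 2 `Cc1nc(C)c(C(=O)Oc2cccc(/C=C/C(=O)O)c2)nc1C` have both been tested in a functional assay on EA.hy 926 cells (Homo sapiens) for cytotoxicity, read by MTT assay, with stated times of 24 h and 12 h, tested at 50 uM; a higher number here means a stronger effect of the compound at the concentration tested, a lower number a weaker effect. In this assay compound 1 gives 89%, and compound 2 gives 75.3%. Compound 2 thus holds the lower of the two numbers, and its distance from compound 1 is wider than the usual scatter of repeated measurements. Compound 3 `CCOC(=O)/C=C/c1cccc(OC(=O)c2nc(C)c(C)nc2C)c1` has not yet been measured. It differs from compound 2 in one place: ethyl in place of hydrogen on an oxygen next to a carbonyl group. Going by the values given here, no pair of measured compounds differs in exactly this way, so the size of the step cannot be read off directly. Some rise seems more likely than a fall, because the ethyl-bearing compound 1 gives 89% while the hydrogen-bearing compound 2 gives 75.3%, though these two also differ elsewhere. Compound 3 is therefore expected to give about 84%, with a likely range of 72% to 95%. The expected step is a number 8.7 percentage points higher from compound 2 to compound 3 (within the scatter), a moderate increase in this assay.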

Compound 3, a percentage reported as activity, at one concentration (the size of the read-out at that concentration, not a potency): 39.5%
For compound 3 the middle estimate is 44.5 percentage points above the measured one, outside the stated range (below it).
By their numbers in this assay, from the lowest: compound 3; then compound 2; then compound 1.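

In this assay, ethyl in place of hydrogen on an oxygen next to a carbonyl group is a clear loss in this setting, with a number 35.8 percentage points lower from compound 2 to compound 3 (beyond the scatter). The ethoxycarbonyl group therefore does not bring a high number by itself, since the methoxy on an aromatic carbon also counts: hydrogen in its place gives a number 49.5 percentage points lower from compound 1 to compound 3 (beyond the scatter). Both changes thus have large effects on the same core, although nothing available explains why these steps are so large. From the compounds shown here alone, whether a longer chain such as propyl, or an amide in place of the ethoxycarbonyl group, would stay close to compound 3 remains open. So does the reading of a compound combining the carboxy group with the methoxy, which would show whether these two changes act independently.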